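The compounds below may be only part of what the source reports. "The series", "measured", "known", "first", "only" and "open" are said of these compounds alone.

Compound 1 `O=C(Cc1csc2nc(-c3ccc(Br)cc3)cn12)N/N=C/c1ccccc1O` gives 13500 nM in a functional assay on MDA-MB-435 cells (Homo sapiens) for inhibition, read by sulforhodamine B assay, with a stated time of 48 h; on this read-out lower numbers stand for stronger inhibition of growth and higher numbers for weaker inhibition of growth.
Compound 2 `COc1cccc(OC)c1/C=N/NC(=O)Cc1csc2nc(-c3ccc(Br)cc3)cn12` gives 16200 nM in this assay.

On these two numbers compound 1 stands lowest, although the step of a 1.2-fold higher number from compound 1 to compound 2 (0.08 log units; within the scatter) is within the scatter, so the two compounds cannot be ordered. Compound 3 `O=C(Cc1csc2nc(-c3ccc(Br)cc3)cn12)N/N=C/c1ccc(Cl)cc1Cl` differs from compound 1 by 2,4-dichlorophenyl in place of 2-hydroxyphenyl on a carbon with a double bond to nitrogen. Among the measured compounds shown here, the only measured step that bears on the same position is a 1.2-fold higher number from compound 1 to compound 2 (0.08 log units; within the scatter), which shows that a change of the group on this carbon left the read-out essentially unchanged. Compound 3 is therefore expected to stay near compound 1, with a step of a 1.0-fold higher number from compound 1 to compound 3 (0.02 log units; within the scatter) not beyond the scatter, and its value is estimated at 14000 nM, within 6000 nM to 35000 nM.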

Compound 3, concentration for total growth inhibition: > 100000 nM
Compound 3: no number, only a limit; the forecaster's own chance of this, stated with the estimate: 10%; middle value at least 7.1-fold (0.85 log units) away from the limit.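

Here 2,4-dichlorophenyl on a carbon with a double bond to nitrogen brings an at least 7.4-fold higher number from compound 1 to compound 3 (0.86 log units; beyond the scatter) and an at least 6.1-fold higher number from compound 2 to compound 3 (0.79 log units; beyond the scatter) in this assay, so this position is not indifferent to its group, as the earlier pair alone might have suggested. The reading for compound 3 is a limit of the assay and not a number: the limit of > 100000 nM in this assay, at which 1 of the 3 values shown sits.

As far as these compounds go, whether a phenyl ring carrying a single chlorine, an amine or a carboxylic acid would stay near compound 1 remains open. So does the true value of compound 3.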